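The compounds below may be only part of what the source reports. "The series", "measured", "known", "first", "only" and "open" are said of these compounds alone.

Compound 1, `Cc1nc(C(=O)Nc2ccc(Cl)c(-c3nnc4c(Cl)cccn34)c2)cs1`, stands in a functional assay on T47D cells (Homo sapiens) for antiproliferative activity, read by MTT assay, with a stated time of 72 h (a lower number here means a stronger inhibitor, a higher number a weaker inhibitor), at > 100000 nM, which is a limit of the assay rather than a measured number. Compound 2, `O=C(Nc1ccc(Cl)c(-c2nnc3c(Cl)cccn23)c1)c1c(F)cccc1Cl`, also gives in this assay a limit, > 100000 nM. Compound 3, `O=C(Nc1ccc(Cl)c(-c2nnc3c(Cl)cccn23)c1)c1ccccc1Cl`, gives in this assay a measured value of 83800 nM. The step that the two limits leave unreadable from compound 1 to compound 2 cannot be read, because the limit of > 100000 nM in this assay, at which 2 of the 3 values shown sit, holds both of its values. Among the measured compounds shown here, the steps of an at least 1.1-fold lower number from compound 1 to compound 3 (0.07 log units; that floor lies within the scatter) and an at least 1.1-fold lower number from compound 2 to compound 3 (0.07 log units; that floor lies within the scatter) show only that compound 3 sits somewhat under that limit.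

Compound 4, `CS(=O)(=O)c1cccc(C(=O)Nc2ccc(Cl)c(-c3nnc4c(Cl)cccn34)c2)c1`, differs from compound 1 by 3-(methylsulfonyl)phenyl in place of 2-methyl-1,3-thiazol-4-yl on a carbonyl carbon. The measured changes on the same carbonyl carbon, from compound 1 to compound 2 and to compound 3, moved the number little or not readably, so little shift beyond the scatter is expected here either. Compound 4 is therefore expected to sit near 100000 nM, within 40000 nM to 300000 nM, a step of a number no higher from compound 1 to compound 4 (the limit leaves the size open), and it may well again come back as a limit.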

Compound 4, half-maximal inhibitory concentration: > 100000 nM
Compound 4: no number, only a limit (the forecaster's own chance of this, stated with the estimate: 60%); the middle value lies on the limit itself.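

Compound 4 is a third compound with a different group on this carbonyl carbon that gives only a limit in this assay, and compound 3 remains the only one of the four with a measured value. The change from 2-chlorophenyl to 3-(methylsulfonyl)phenyl gives an at least 1.1-fold higher number from compound 3 to compound 4 (0.07 log units; that floor lies within the scatter), so it does not separate these two groups. The steps joining compound 4 to compound 1 and compound 2 cannot be read, because all three compounds rest on one shared limit: the limit of > 100000 nM in this assay, at which 3 of the 4 values shown sit.

The compounds shown leave open whether any group on this carbonyl carbon can give a readable gain in this assay. From the compounds shown here alone, it also remains open whether a piperidine ring or a benzoic acid in this place would give a measured value at all.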